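A few compounds are considered here, and "the series" means these few. Any claim that something is new, unique, unknown or untested is made for them only; others in the source may bear on it.

Compound 1, `C/C(=N\Cc1ccccc1)c1c(O)c2ccccc2[nH]c1=O`, in an assay on isolated protein for inhibition of myosin-2 (Bos taurus), read by spectrophotometry, with a stated time of 24 min (on this read-out lower numbers stand for stronger inhibition and higher numbers for weaker inhibition), gives >= 100000 nM, a limit of the assay.
Compound 2, `C/C(=N\Cc1cccnc1)c1c(O)c2ccccc2oc1=O`, in this assay gives 17000 nM.
Compound 3, `C/C(=N\Cc1ccccc1C)c1c(O)c2ccccc2oc1=O`, in this assay gives >= 100000 nM, a limit of the assay.

Going by the values given here, compound 2 stands as the only actual number among the three; the other two are limits. Compound 4, `C/C(=N\C(C)C)c1c(O)c2ccccc2oc1=O`, differs from compound 2 by isopropyl in place of (pyridin-3-yl)methyl on a double-bonded nitrogen. Among the compounds with values here, the one measured step that bears on this is an at least 5.8-fold higher number from compound 2 to compound 3 (0.76 log units; beyond the scatter), where losing the pyridine ring ended at the limit of >= 100000 nM in this assay, at which 2 of the 3 values shown sit. Swapping the whole ring-bearing arm for a short isopropyl group is expected to move in the same direction, so a step of about a 3.5-fold higher number from compound 2 to compound 4 (0.55 log units; beyond the scatter) is estimated. Compound 4 is therefore expected to give about 60000 nM, within 15000 nM to 200000 nM, with a real chance that only a limit is recorded.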

Compound 4, half-maximal inhibitory concentration: >= 100000 nM
Compound 4: a limit, no number (the forecaster's own chance of this, stated with the estimate: 55%); at least 1.6-fold (0.22 log units) between middle value and limit.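

Putting isopropyl in place of (pyridin-3-yl)methyl on a double-bonded nitrogen gives an at least 5.8-fold higher number from compound 2 to compound 4 (0.76 log units; beyond the scatter) and so shows that a short group with no ring ends at the same limit as the 2-methylphenyl arm of compound 3. Among compound 2, compound 3 and compound 4, only compound 2 gives an actual number. The true size of this step stays unknown because the reading stops at a limit: the limit of >= 100000 nM in this assay, at which 3 of the 4 values shown sit.

On these data alone, compound 3 and compound 4 cannot be ordered against each other, so how much the ring itself matters stays open. So does whether an amine, a carboxylic acid or a longer chain ending in pyridin-3-yl would give a number here.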